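The source may report more compounds than this note shows. Statements on the series, on what has been measured and on what is new or still open speak of the compounds shown alone.

Measured so far:
compound 1, `CCCCCCCCCCCCCCCCCCNC(=O)[C@H]1CSC(c2c[nH]c3ccccc23)N1`, in a functional assay on TSU-Pr1 cells for antiproliferative activity against TSU (Homo sapiens), read by sulforhodamine B assay (on this read-out lower numbers stand for stronger inhibition and higher numbers for weaker inhibition), gives 4400 nM.
compound 2, `CCCCCCCCCCCCCCCCCCNC(=O)[C@H]1CSC(c2cc(F)cc(F)c2)N1`, in this assay gives > 20000 nM, which is a limit of the assay rather than a number.

Compound 2 therefore stands at the weak end of what has been measured: its value is a limit, so its true strength is not known beyond that. Among the measured compounds shown here, the one measured step, an at least 4.5-fold higher number from compound 1 to compound 2 (0.65 log units; beyond the scatter), runs toward that limit, as the limit of > 20000 nM in this assay, at which 1 of the 2 values shown sits, makes plain.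

The next compound, compound 3, `CCCCCCCCCCCCCCCCCCNC(=O)[C@H]1CSC(c2ccc(C)cc2)N1`, differs from compound 2 in a single place: 4-methylphenyl in place of 3,5-difluorophenyl on a saturated ring carbon. For the measured compounds named here, no measured step swaps one substituted phenyl ring for another, so the only guidance is that compound 2 already sits at the limit. With nothing to suggest a turn in either direction, the step from compound 2 to compound 3 is expected to be small or absent, a step that the limit leaves unreadable from compound 2 to compound 3, and compound 3 is expected to give about 25000 nM in this assay, within a range from 6000 nM to 100000 nM, with a real chance that only a limit is reported again.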

Compound 3, half-maximal inhibitory concentration: 8000 nM
For compound 3 the middle estimate is 3.1-fold (0.49 log units) above the measured one; low and high end bracket the measured number.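

On this saturated ring carbon, the groups on the phenyl ring matter in this assay: with the ring itself kept, 4-methylphenyl in place of 3,5-difluorophenyl gives an at least 2.5-fold lower number from compound 2 to compound 3 (0.39 log units; beyond the scatter). Among the compounds shown here, the 1H-indol-3-yl group of compound 1 is also not the only group that gives a measurable value here, as the change to 4-methylphenyl gives a 1.8-fold higher number from compound 1 to compound 3 (0.26 log units; within the scatter), so these two groups cannot be told apart in this assay. The value of compound 2 is a limit, not a number: the limit of > 20000 nM in this assay, at which 1 of the 3 values shown sits.

Nothing shown separates the gain from adding the methyl group from the gain from losing the two fluorines, since both changes come together in one step. A plain phenyl ring, a 4-fluorophenyl group or a 4-methoxyphenyl group would help to show whether the result depends on the methyl group itself, or on the absence of fluorine, and whether other groups at this position would follow the same trend.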